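Pyrazole for Sec-Butyl on the Amide Nitrogen

The source may hold more compounds than are shown below. What is called first, only, known or untested is meant among the compounds shown, and "the series" means these compounds.

Compound 1 `CCC(C)N(Cc1cccs1)C(=O)COc1ccc(C)cc1` belongs to a small set of three aryloxyacetamides tested in an assay on HEK293 cells for agonist activity at transient receptor potential cation channel subfamily M member 8 (Homo sapiens), read by fluorescence and calcium flux, with a stated time of 15 min (on this read-out higher numbers stand for an effect only at larger amounts of compound and lower numbers for an effect already at smaller amounts), where compound 1 gives 2000 nM. Compound 2 `CCN(Cc1cccs1)C(=O)COc1ccc(C(C)C)cc1` gives 397 nM in this assay, and compound 3 `CCN(Cc1cccn1C)C(=O)COc1ccc(C)cc1` gives 21300 nM. On these numbers compound 1 stands second highest of the three: compound 2 sits lower by a gap beyond the usual scatter, and compound 3 sits higher, also beyond the scatter. Among the compounds with values here, no pair among the three differs in just one place, so no single change can be traced from the measured values.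

The step under consideration leads to compound 4 `Cc1ccc(OCC(=O)N(Cc2cccs2)c2cn[nH]c2)cc1`, which differs from compound 1 by 1H-pyrazol-4-yl in place of sec-butyl on an amide-type nitrogen. The measured compounds give no guide to this change, since the substituents on the amide-type nitrogen in compounds 1, 2 and 3 are all saturated chains. The move to a ring with a hydrogen-bond donor and acceptor on that nitrogen is therefore an open question. The step of a 2.0-fold higher number from compound 1 to compound 4 (0.30 log units; within the scatter) is expected to be a modest rise in the number, with wide uncertainty either way. Compound 4 is thus estimated at 4000 nM, within a range from 800 nM to 20000 nM.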

Compound 4, half-maximal effective concentration: 1.4 nM
For compound 4 the middle estimate is 2900-fold (3.46 log units) above the measured one, and the stated range ends above it.
By their numbers in this assay, from the lowest: compound 4; then compound 2; then compound 1; then compound 3.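

In this assay, replacing sec-butyl with 1H-pyrazol-4-yl on the amide-type nitrogen gives a 1400-fold lower number from compound 1 to compound 4 (3.15 log units; beyond the scatter) and so shows that this position is highly sensitive to the group it carries. The earlier compounds shown here had only saturated chains here and offered no step in a single place, whereas this change brings in a five-membered aromatic ring with a hydrogen-bond donor and a hydrogen-bond acceptor, where sec-butyl has neither. No supporting measurement is available to explain a step of this size.

The compounds shown leave open whether the step depends on the ring nitrogens, the amide-type nitrogen's hydrogen-bond donor or the aromatic ring itself, a question that phenyl or 1-methylpyrazol-4-yl on the same nitrogen would help to separate. They also leave open whether 1H-pyrazol-4-yl would have a similar effect if the isopropyl group of compound 2 replaced the methyl group of compound 4.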